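A smaller group on the ring nitrogen of compound 3

The source may report more compounds than this note shows. Statements on the series, on what has been measured and on what is new or still open speak of the compounds shown alone.

compound 1 `O=C(NO)c1cnc(N2CCN(S(=O)(=O)c3ccc4ccccc4c3)CC2)s1`: 2000 nM
compound 2 `Cc1ccc(S(=O)(=O)N2CCN(c3ncc(C(=O)NO)s3)CC2)cc1`: 350 nM
compound 3 `CC(=O)N1CCN(c2ncc(C(=O)NO)s2)CC1`: > 100000 nM

All three share one core. In a functional assay on MCF7 cells (Homo sapiens) for antiproliferative activity (on this read-out higher numbers stand for weaker inhibition of growth and lower numbers for stronger inhibition of growth), compound 1 gives 2000 nM and compound 2 gives 350 nM. For compound 3 the value > 100000 nM is a limit of this assay and not a number (the limit of > 100000 nM in this assay, at which 1 of the 3 values shown sits). Compound 3 thus stands at the edge of what this assay can report. Compound 4 `CN1CCN(c2ncc(C(=O)NO)s2)CC1` is not yet measured. It differs from compound 3 by methyl in place of acetyl on an amine nitrogen in a ring. Within the data shown here, with no measured step of this kind to lean on, no shift beyond the scatter is expected, and the step of a number no higher from compound 3 to compound 4 (the limit leaves the size open) is estimated as flat. Compound 4 is expected to give about 100000 nM in this assay, within 20000 nM to 500000 nM, with a real chance that again only a limit is reported.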

Compound 4, concentration for 50% growth inhibition: > 100000 nM
Compound 4: a limit, no number; the forecaster's own chance of this, stated with the estimate: 60%; the middle value lies on the limit itself.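

Compound 3 and compound 4 both give only a limit in this assay, not a number, so no step between them can be read: the limit of > 100000 nM in this assay, at which 2 of the 4 values shown sit.

The compounds shown leave open whether methyl in place of acetyl on the ring nitrogen changes growth inhibition at all.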